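The source may hold more compounds than are shown below. What is called first, only, known or untested is meant among the compounds shown, and "the series" means these compounds.

Measured compounds: compound 1 `COc1cc(-c2nn(-c3cccc(NC(=O)Nc4cc(C(F)(F)F)cc(C(F)(F)F)c4)c3)cc2-c2ccncc2)ccc1Cl` with 7680 nM in a functional assay on Malme-3M cells (Homo sapiens) for inhibition, read by sulforhodamine B assay, with a stated time of 48 h; a lower number here means that less compound is tolerated, a higher number that more compound is tolerated; compound 2 `COc1cc(-c2nn(-c3cccc(NC(=O)Nc4cccc(C(F)(F)F)c4)c3)cc2-c2ccncc2)ccc1Cl` with 33900 nM in this assay.

Compound 2 stands at the highest of the two numbers in this assay, and its nearest neighbour is compound 1, whose step a 4.4-fold higher number from compound 1 to compound 2 (0.64 log units; beyond the scatter) arose from hydrogen in place of trifluoromethyl on an aromatic carbon. Compound 3 `COc1cc(-c2nn(-c3cccc(NC(=O)c4ccccc4)c3)cc2-c2ccncc2)ccc1Cl` differs from compound 2 by phenyl in place of (3-(trifluoromethyl)phenyl)amino on a carbonyl carbon whose other neighbours are an amide-type nitrogen. Among the compounds with values here, only the step from compound 1 to compound 2 bears on this change, and it shares with it the loss of a trifluoromethyl group; the further loss of the amino part and the donor it carried has no measured counterpart here. That one step was modest and pointed toward a higher number, so a further rise beyond the scatter is expected for compound 3 in this assay, of about a 2.1-fold higher number from compound 2 to compound 3 (0.31 log units; beyond the scatter). Compound 3 is therefore estimated at 70000 nM, with a range from 25000 nM to 200000 nM.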

Compound 3, concentration lethal to 50% of the cells: > 100000 nM
Compound 3: only a limit was reported; the forecaster's own chance of this, stated with the estimate: 30%; middle value at least 1.4-fold (0.15 log units) away from the limit.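

With an at least 2.9-fold higher number from compound 2 to compound 3 (0.46 log units; beyond the scatter), the step shows that the number in this assay also responds to what sits on the carbonyl carbon whose other neighbour is an amide-type nitrogen, whereas the earlier step changed only the trifluoromethyl count and left the amino link in place. Both steps shown run toward a higher number, and neither of the compounds' steps goes against this, though two steps make a thin basis for any trend. Compound 3 carries a limit of the assay rather than a number, so its step gives only a minimum size, and the true distance from compound 2 stays unknown: the limit of > 100000 nM in this assay, at which 1 of the 3 values shown sits.

The change removes the amino part, with its hydrogen-bond donor, and the trifluoromethyl group together, so the compounds shown leave open which of the two accounts for the step. They also leave open how this carbonyl carbon would read with 3-(trifluoromethyl)phenyl attached directly, or with a benzylamino group or a piperidine in place of the phenyl.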